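The compounds below may be only part of what the source reports. "The series", "measured", "known", "first", "only" and "open" are said of these compounds alone.

Compound 1 `O=S(=O)(Nc1ccc(-c2nc3ccccc3o2)cc1)c1cccc(Cl)c1` gives 54000 nM in an assay on cells for inhibition of HSP60/HSP10 (Homo sapiens), with a stated time of 60 min; a higher number here means a weaker inhibitor, a lower number a stronger inhibitor. Compound 2 `O=S(=O)(Nc1ccc(-c2nc3ccccc3o2)cc1)c1ccccc1O` returns only a limit in this assay, namely > 100000 nM. Compound 3 `Cc1ccccc1S(=O)(=O)Nc1ccc(-c2nc3ccccc3o2)cc1` gives 85000 nM in this assay.

Compound 3 thus sits beside compound 1, the step of a 1.6-fold higher number from compound 1 to compound 3 (0.20 log units; within the scatter) lying within the scatter, while compound 2 offers only a limit (the limit of > 100000 nM in this assay, at which 1 of the 3 values shown sits). Compound 4 `C=Cc1ccc(S(=O)(=O)Nc2ccc(-c3nc4ccccc4o3)cc2)cc1` differs from compound 3 by 4-vinylphenyl in place of 2-methylphenyl on a sulfonyl sulfur. Within the data shown here, the steps that bear on this exchange of the aryl group on the sulfonyl sulfur are an at least 1.8-fold higher number from compound 1 to compound 2 (0.26 log units; that floor lies within the scatter) and a 1.6-fold higher number from compound 1 to compound 3 (0.20 log units; within the scatter), and the step of an at least 1.1-fold lower number from compound 2 to compound 3 (0.07 log units; that floor lies within the scatter); none of them exceeds the scatter. Compound 4 is therefore expected to show no step beyond the scatter, with a 1.2-fold lower number from compound 3 to compound 4 (0.08 log units; within the scatter). The estimated value of compound 4 in this assay is 70000 nM, within 30000 nM to 150000 nM.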

Compound 4, half-maximal inhibitory concentration: > 100000 nM
Compound 4 gave a limit, no number; the forecaster's own chance of this, stated with the estimate: 30%; at least 1.4-fold (0.15 log units) between middle value and limit.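

Placing 4-vinylphenyl on the sulfonyl sulfur extends the earlier picture to a larger group with a double bond outside the aromatic ring, and still no step beyond the scatter can be shown: an at least 1.1-fold higher number from compound 3 to compound 4 (0.07 log units; that floor lies within the scatter) and an at least 1.8-fold higher number from compound 1 to compound 4 (0.26 log units; that floor lies within the scatter). The step from compound 2 to compound 4 cannot be read, and a second compound now rests on the same limit: the limit of > 100000 nM in this assay, at which 2 of the 4 values shown sit.

On these data alone, whether a phenyl group carrying an amine or a carboxylic acid on the sulfonyl sulfur would give a step beyond the scatter stays open.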